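Cytotoxicity of an Amide Series on Normal Colon Cells

The source may report more compounds than this note shows. Statements on the series, on what has been measured and on what is new or still open speak of the compounds shown alone.

Compound 1 `Cc1ccc(NC(=O)c2cccc(/C=C3\CC(=O)N(c4ccccc4)C3=O)c2)cc1` was examined in an ADME assay on NCM460 cells (Homo sapiens) for cytotoxicity, read by MTT assay, with a stated time of 72 h; a higher number here means a weaker inhibitor, a lower number a stronger inhibitor. In this assay compound 1 gives > 100000 nM, which is a limit of the assay and not a number. Two related compounds fall at the same limit. Compound 2 `CCCCCN1C(=O)C/C(=C\c2cccc(C(=O)Nc3ccc(C)cc3)c2)C1=O` carries pentyl in place of phenyl on an amide-type nitrogen in a ring, and in this assay compound 2 gives > 100000 nM, again a limit. Compound 3 `Cc1ccc(N2C(=O)C/C(=C\c3cccc(C(=O)Nc4ccc(Cl)cc4)c3)C2=O)cc1` in this assay gives > 100000 nM, also a limit. The step that the two limits leave unreadable from compound 1 to compound 2 therefore cannot be read. Compound 1 thus stands at the limit together with both other measured compounds, as the limit of > 100000 nM in this assay, at which 3 of the 3 values shown sit, records.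

Compound 4 `O=C(NCC1CCCCC1)c1cccc(/C=C2\CC(=O)N(c3ccccc3)C2=O)c1` differs from compound 1 by cyclohexylmethyl in place of 4-methylphenyl on an amide-type nitrogen. Among the compounds with values here, no measured step touches this position on the amide-type nitrogen whose other neighbour is the carbonyl carbon, and the one measured step, on the ring nitrogen, is unreadable. Because the limit of > 100000 nM in this assay, at which 3 of the 3 values shown sit, places every shown value at the limit, compound 4 is expected to sit there too, with a step that the limit leaves unreadable from compound 1 to compound 4 expected to be none beyond the scatter. Compound 4 is estimated in this assay at 150000 nM, within a range from 60000 nM to 400000 nM.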

Compound 4, half-maximal inhibitory concentration: > 100000 nM
Compound 4 ended at the assay's limit; the forecaster's own chance of this, stated with the estimate: 85%; the middle value lies beyond the limit too.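

In this assay compound 4 gives > 100000 nM, which is a limit of the assay and not a number. The step between compound 1 and compound 4 therefore cannot be read, and both sit at the same mark: the limit of > 100000 nM in this assay, at which 4 of the 4 values shown sit.

The compounds shown leave open whether a change on either amide-type nitrogen alters the read-out at all.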